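Trading a Piperazine for a Methylpyrrolidinylamine

A few compounds are considered here, and "the series" means these few. Any claim that something is new, unique, unknown or untested is made for them only; others in the source may bear on it.

Of the compounds shown here, three sharing one core have been measured in a physicochemical assay for lipophilicity; a higher number here means a more lipophilic compound, a lower number a more polar compound. Compound 1 `N[C@H]1CC[C@H](Nc2ccc3ncc(-c4cnc(Nc5ncc(C(F)(F)F)cc5F)nc4)n3n2)CC1` gives 1.6. Compound 2 `Cc1ccc(Nc2ncc(-c3cnc4ccc(N[C@H]5CC[C@H](N)CC5)nn34)cn2)nc1` gives 1.1 in this assay, and the change from compound 1 to compound 2, 5-methylpyridin-2-yl in place of 3-fluoro-5-(trifluoromethyl)pyridin-2-yl on a nitrogen on an aromatic ring, brings a number 0.50 log units lower from compound 1 to compound 2 (beyond the scatter). Compound 3 `Fc1cccnc1Nc1ncc(-c2cnc3ccc(N4CCNCC4)nn23)cn1` gives 0.7 in this assay, the lowest of the three numbers, sitting beyond the scatter under compound 2 and further still under compound 1.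

The step of interest leads from compound 3 to compound 4 `CN1CC[C@H](Nc2ccc3ncc(-c4cnc(Nc5ncccc5F)nc4)n3n2)C1`, which has not yet been measured in this assay. The change is (1-methylpyrrolidin-3-yl)amino in place of piperazin-1-yl on an aromatic carbon. Among the compounds with values here, no measured pair in this set alters the same part of the molecule; the only recorded step, from compound 1 to compound 2, concerns the substituted pyridine and so offers no direct guide here. With compound 3 already the lowest number in this assay, and the entering group carrying the atoms counted above, compound 4 is expected to give 1, between 0.5 and 1.5. That estimate means a step of a number 0.30 log units higher from compound 3 to compound 4 (within the scatter) from compound 3 to compound 4, a modest rise whose size is uncertain in the absence of a matching measured step.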

Compound 4, distribution coefficient: 1.5
Beside the measured number, compound 4's estimate is 0.50 log units below it, within the range that was stated.
By their numbers in this assay, from the lowest: compound 3; then compound 2; then compounds 4 and 1 (each within the scatter of the next).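

Placing (1-methylpyrrolidin-3-yl)amino in place of piperazin-1-yl on this aromatic carbon of the shared core gives, in this assay, a number 0.80 log units higher from compound 3 to compound 4 (beyond the scatter), so this position, which no earlier pair had touched, can move the reading beyond the scatter. The earlier compounds had shown a change only at the pyridine, through a number 0.50 log units lower from compound 1 to compound 2 (beyond the scatter), whereas the new step shows that the group on the far side of the core matters too, even though the two groups have the same counts of hydrogen-bond donors and acceptors and neither carries a net charge. No measurement here accounts for the rise.

Within the data shown here, the single step combines several changes, a five-membered ring for a six-membered one, an amino link and a methyl group on the ring nitrogen, and a 4-methylpiperazin-1-yl or an unsubstituted pyrrolidin-3-ylamino group on the same carbon would begin to separate them. Also open, going by these compounds, are the effect of the opposite stereocentre and whether the step would be of similar size with 5-methylpyridin-2-yl on the other side of the molecule.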